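Compound 3 and the Step from Compound 2

The source may report more compounds than this note shows. Statements on the series, on what has been measured and on what is new or still open speak of the compounds shown alone.

Measured so far in a functional assay on HeLa cells (Homo sapiens) for cytotoxicity, read by MTT assay, with a stated time of 24 h; on this read-out lower numbers stand for stronger inhibition and higher numbers for weaker inhibition
Compound 1 `CN1C/C(=C\c2ccc(C#N)cc2)C(=O)/C(=C/c2ccccc2F)C1` gives 1340 nM
Compound 2 `COc1cc(/C=C2\CN(C)C/C(=C\c3ccc(F)cc3)C2=O)cc(OC)c1` gives 10200 nM

Within the data shown here, of these two numbers, the one for compound 2 (10200 nM) is the higher and so marks the weaker inhibition. Compound 1 (1340 nM) lies below it by a margin beyond the scatter. The two compounds differ in more than one place, so this gap cannot be assigned to any single change.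

Compound 3 `COc1cc(/C=C2\CN(C)C/C(=C\c3cccc([N+](=O)[O-])c3)C2=O)cc(OC)c1` differs from compound 2 in one place, with 3-nitrophenyl in place of 4-fluorophenyl on a double-bonded chain carbon bound to a double-bonded ring carbon. Among the measured compounds shown here, no measured pair shows this exchange, so the data offer no direct guide to its size in this assay. For the measured compounds named here, the only hint is that compound 1 (1340 nM) shows lower numbers are reachable. A modest move toward a lower number is therefore expected, and it may not clear the scatter (a 2.3-fold lower number from compound 2 to compound 3 (0.36 log units; beyond the scatter)). For compound 3 the estimated value is 4500 nM (expected range 1300 nM to 13000 nM).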

Compound 3, half-maximal inhibitory concentration: 2560 nM
For compound 3 the middle estimate is 1.8-fold (0.24 log units) above the measured one; the measured number falls inside the stated range.
By their numbers in this assay, from the lowest: compounds 1 and 3 (each within the scatter of the next); then compound 2.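

In this assay the exchange of 4-fluorophenyl for 3-nitrophenyl on a double-bonded chain carbon bound to a double-bonded ring carbon gives a 4.0-fold lower number from compound 2 to compound 3 (0.60 log units; beyond the scatter), so a change at this one place is now seen to move the read-out, which the earlier pair, differing in more than one place, could not show. The entering 3-nitrophenyl keeps the six-membered aromatic ring of carbon only and has 2 hydrogen-bond acceptors where 4-fluorophenyl has 0, but this single exchange does not separate the loss of fluorine, the arrival of the nitro group and the different placing of the two groups on the ring. Nothing measured here accounts for the step.

From the compounds shown here alone, whether an amine or a carboxylic acid in place of the nitro group would move the number in the same direction, or by a similar amount, remains open. Also open, going by these compounds, is whether the same exchange would give a step of like size on the core of compound 1, which carries other groups elsewhere.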